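A few compounds are considered here, and "the series" means these few. Any claim that something is new, unique, unknown or untested is made for them only; others in the source may bear on it.

The series rests on two cores. Compound 1 `Cc1cccc2c(NCc3ccco3)nc(NC(C)C)nc12` and compound 2 `Cc1ccc2nc(NC(C)C)nc(NCc3ccco3)c2c1` are built from the same atoms joined differently; the difference between the two cores is not broken down here. Compound 3 `COc1cccc2c(NCc3ccco3)nc(NC(C)C)nc12` carries the core of compound 1 with the change (methoxy in place of methyl on an aromatic carbon). Compound 4 `COc1ccc2nc(NC(C)C)nc(NCc3ccco3)c2c1`, not yet measured, carries the core of compound 2 with the change (methoxy in place of methyl on an aromatic carbon).

In a physicochemical assay for permeability, using PAMPA, at pH 7.4 (a higher number here means that the compound crosses the layer faster, a lower number that the compound crosses the layer more slowly), compound 1 gives 666 10^-6 cm/s. Compound 2 gives 789 10^-6 cm/s, and compound 3 gives 1060 10^-6 cm/s. For the measured compounds named here, the only measured step along a single change, a 1.6-fold higher number from compound 1 to compound 3 (0.20 log units; within the scatter), stays within the scatter, so on the core of compound 1 the methoxy and methyl analogues cannot be told apart in this assay. Compound 2 and compound 1 also lie within the scatter of each other, as do compound 2 and compound 3.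

Going by the values given here, the change from compound 2 to compound 4 is the same kind of change as the one from compound 1 to compound 3, but not the same: in compound 3 the methoxy sits ortho to a fused ring and meta to a fused ring, whereas in compound 4 it sits meta to a fused ring and para to a fused ring. With a single earlier instance, itself within the scatter, the expected step in this assay is a 1.3-fold higher number from compound 2 to compound 4 (0.10 log units; within the scatter), resting on a 1.6-fold higher number from compound 1 to compound 3 (0.20 log units; within the scatter). For compound 4 the estimate in this assay is 1000 10^-6 cm/s, with a likely range from 600 10^-6 cm/s to 1600 10^-6 cm/s.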

Compound 4, apparent permeability: 1010 10^-6 cm/s
Estimate against measurement, compound 4: 1.0-fold (0.00 log units) below, and the stated range covers the measured number.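

In this assay the new step is a 1.3-fold higher number from compound 2 to compound 4 (0.11 log units; within the scatter) and the earlier step on the other core is a 1.6-fold higher number from compound 1 to compound 3 (0.20 log units; within the scatter), so methoxy in place of methyl on an aromatic carbon stays within the scatter on both cores, and in compound 4 the methoxy sits meta to a fused ring and para to a fused ring. The change therefore carries from one core to the other without a step beyond the scatter in these two pairs, but methoxy and methyl cannot be told apart on either core, no real effect of the change is shown, and two pairs give no rule for any further core or place. Nothing shown bears on why both steps remain this small.

The compounds shown leave open whether a group other than methyl or methoxy on this aromatic carbon, such as a nitrile, an amine or a carboxylic acid, would give a step beyond the scatter on either core. They also leave open whether methoxy at a different place on a single core would give a step that can be read in this assay at all.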